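The source may hold more compounds than are shown below. What is called first, only, known or untested is meant among the compounds shown, and "the series" means these compounds.

Measured in an ADME assay on microsomes from liver (Homo sapiens) for metabolic stability, read by LC-MS, using NADPH, with stated times of 5 min and 30 min, tested at 1 uM; on this read-out higher numbers stand for fast clearance and lower numbers for slow clearance:
- compound 1 `O=C(Nc1ccccc1)c1cnc(NCc2c(F)ccc3c2CCO3)n2cnnc12`: 14 mL.min-1.g-1
- compound 2 `O=C1CCCN1c1cnc(NCc2c(F)ccc3c2CCO3)c2cn[nH]c(=O)c12`: 23 mL.min-1.g-1
- compound 3 `COCCC(=O)Nc1cnc(NCc2c(F)ccc3c2CCO3)n2cnnc12`: < 3 mL.min-1.g-1, a limit and not a number

For the measured compounds named here, compound 2 lies within the scatter of compound 1, and these are the only two numbers in hand. Compound 4 `Cc1cc(-c2cnc(NCc3c(F)ccc4c3CCO4)c3cn[nH]c(=O)c23)n(C)n1` carries 1,3-dimethyl-1H-pyrazol-5-yl in place of 2-oxopyrrolidin-1-yl on an aromatic carbon. Going by the values given here, no measured step starts from compound 2. Among the compounds with values here, the one available step, an at least 4.6-fold lower number from compound 1 to compound 3 (0.66 log units; beyond the scatter), exchanges other groups on a different core, so it shows only that a single exchange can pass the scatter, and it sets neither size nor direction here. The estimated step is a 1.2-fold higher number from compound 2 to compound 4 (0.09 log units; within the scatter), not expected to pass the scatter, though with wide uncertainty. For compound 4 the estimate is 28 mL.min-1.g-1, with an expected range of 10 mL.min-1.g-1 to 70 mL.min-1.g-1.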

Compound 4, intrinsic clearance in microsomes: 24 mL.min-1.g-1
Beside the measured number, compound 4's estimate is 1.2-fold (0.07 log units) above it, within the range that was stated.
By their numbers in this assay, from the lowest: compounds 1, 2 and 4 (each within the scatter of the next). At a limit, below all of these: compound 3.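

At this aromatic carbon of the shared core, 1,3-dimethyl-1H-pyrazol-5-yl and 2-oxopyrrolidin-1-yl read alike in this assay (a 1.0-fold higher number from compound 2 to compound 4 (0.02 log units; within the scatter)). On this read-out, a five-membered aromatic ring with 2 hetero atoms and a five-membered non-aromatic ring with 1 hetero atom can stand in for one another at this position. No measurement shown gives a cause for this. Still open, going by these compounds, is whether a carboxylic acid or a primary amine here would separate from these two groups. On these data alone, a longer alkyl chain at this position is equally open.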